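Same Substituent Swap on Two Cores, Small Step Expected

The compounds below may be only part of what the source reports. "The series", "measured", "known", "first", "only" and "open" are said of these compounds alone.

Three compounds have so far been measured in a functional assay on A549 cells (Homo sapiens) for antiproliferative activity, read by MTT assay; on this read-out lower numbers stand for stronger inhibition and higher numbers for weaker inhibition:

Compound 1, `COc1ccc2nc(N(Cc3cc(-c4ccc(SC(F)(F)F)cc4)no3)c3nc4ccc(F)cc4s3)sc2c1`: 26500 nM
Compound 2, `COc1ccc2nc(N(Cc3cc(-c4ccc(OC(F)(F)F)cc4)no3)c3nc4ccc(F)cc4s3)sc2c1`: 37100 nM
Compound 3, `FC(F)(F)Sc1ccc(-c2cc(CN(c3ncccn3)c3nc4ccccc4s3)on2)cc1`: 29800 nM

Compound 1 and compound 2 share one core and differ in a single place, (trifluoromethoxy in place of (trifluoromethyl)sulfanyl on an aromatic carbon). The step this made is a 1.4-fold higher number from compound 1 to compound 2 (0.15 log units; within the scatter). Compound 3 is built on a different core; the difference between the two cores is not broken down here. Its value and that of compound 1 lie within the scatter of each other, as do its value and that of compound 2, so no order among the three can be read.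

Compound 4, `FC(F)(F)Oc1ccc(-c2cc(CN(c3ncccn3)c3nc4ccccc4s3)on2)cc1`, has not yet been measured. It differs from compound 3 by trifluoromethoxy in place of (trifluoromethyl)sulfanyl on an aromatic carbon, which is the same change, at the same kind of place, as the one from compound 1 to compound 2; among the compounds shown it occurs twice. Because the step of a 1.4-fold higher number from compound 1 to compound 2 (0.15 log units; within the scatter) stayed within the scatter, the step from compound 3 to compound 4 is expected to be of similar size, a 1.3-fold higher number from compound 3 to compound 4 (0.11 log units; within the scatter). Compound 4 is therefore estimated at 38000 nM, with a range from 18000 nM to 80000 nM.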

Compound 4, half-maximal inhibitory concentration: 31800 nM
Compound 4: middle estimate off by 1.2-fold (0.08 log units), on the high side; the measured number falls inside the stated range.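

On the core of compound 3, trifluoromethoxy in place of (trifluoromethyl)sulfanyl gives a 1.1-fold higher number from compound 3 to compound 4 (0.03 log units; within the scatter) in this assay. Set beside the earlier step, the change shows no difference between the two cores that can be told apart: the same change on two cores in this assay, a 1.4-fold higher number (0.15 log units; within the scatter) from compound 1 to compound 2 and a 1.1-fold higher number (0.03 log units; within the scatter) from compound 3 to compound 4, 1.3-fold (0.12 log units) apart, within the scatter of two such steps

Among the compounds shown here, this shows only that the swap stays within the scatter on both cores; it does not show that the two steps are equal, that the two groups are interchangeable in general, or that the same would hold on any further core, and it rests on just two pairs.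

The compounds shown hold only these two groups on the aromatic carbon para to a large group, so it remains open whether an amine or a carboxylic acid there would give a step beyond the scatter. For the compounds shown here, also open is what the difference between the two cores itself contributes, as no single-place step connects them.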